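The compounds below may be only part of what the source reports. "The series", "measured", "known", "first", "only" and "open" are said of these compounds alone.

Compound 1 `COc1cccc(CNCCCNc2ccnc3cc(Oc4ccc(Cl)cc4)ccc23)c1O`: 317 10^-6 cm/s
Compound 2 `COc1cccc(Oc2ccc3c(NCCCNCc4cc(F)ccc4OC)ccnc3c2)c1`: 317 10^-6 cm/s
Compound 3 `COc1cccc(Oc2ccc3c(NCCCNCc4cccc(OC)c4O)ccnc3c2)c1`: 317 10^-6 cm/s

In an ADME assay for permeability, using PAMPA, with a stated time of 30 min, at pH 7.4 (on this read-out lower numbers stand for lower permeability and higher numbers for higher permeability), compound 2 gives 317 10^-6 cm/s, which stands level with compound 1 and compound 3 within the usual scatter, so nothing separates the three measured compounds on this read-out. The compound still to be measured is compound 4 `COc1ccc(F)cc1CNCCCNc1ccnc2cc(Cc3ccc(C#N)cc3)ccc12`. Its difference from compound 2 is 4-cyanobenzyl in place of 3-methoxyphenoxy on an aromatic carbon.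

Two measured steps have some bearing on this. The step of no change at the digits printed from compound 1 to compound 3 (within the scatter) exchanged the aryl group on an oxygen on an aromatic ring of the shared core and left the read-out unchanged. The step of no change at the digits printed from compound 2 to compound 3 (within the scatter) swapped the substituted benzyl group on the saturated chain carbon bound to an amine nitrogen, again without change. Neither step removed the oxygen link from the core or brought in a nitrile, so the change to compound 4 goes somewhat beyond what has been tested. Even so, with every change made so far leaving this assay flat, the step expected here, a 1.1-fold lower number from compound 2 to compound 4 (0.02 log units; within the scatter), is none beyond the scatter. Compound 4 is therefore estimated at 300 10^-6 cm/s in this assay, with a range from 150 10^-6 cm/s to 400 10^-6 cm/s.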

Compound 4, apparent permeability: 23 10^-6 cm/s
For compound 4 the middle estimate is 13-fold (1.12 log units) above the measured one; measured number outside the range, below it.
By their numbers in this assay, from the lowest: compound 4; then compounds 1, 2 and 3 (each within the scatter of the next).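

In this assay, putting 4-cyanobenzyl in place of 3-methoxyphenoxy on this aromatic carbon gives a 14-fold lower number from compound 2 to compound 4 (1.14 log units; beyond the scatter) and is the first step among these compounds to move the read-out beyond the scatter, so this position does not tolerate every change, although swapping the aryl group on the oxygen (no change at the digits printed from compound 1 to compound 3 (within the scatter)) left the number where it was. The size of the group, counted in atoms, does not separate the two compounds: both the leaving and the entering group have 9 heavy atoms and one six-membered aromatic ring of carbon only, so a large step can occur here with no change in that count. The data shown offer no measurement that explains the step.

This single step removes the oxygen link and the methoxy group and brings in the nitrile all at once, so the compounds shown cannot say which of these changes goes with the lower number. From the compounds shown here alone, a plain benzyl group or a 4-cyanophenoxy group on the same carbon would help to pull these changes apart, and where either would fall on this read-out remains open.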